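A few compounds are considered here, and "the series" means these few. Any claim that something is new, unique, unknown or untested is made for them only; others in the source may bear on it.

In an ADME assay on the whole organism (Mus musculus, strain Swiss Webster) for pharmacokinetics, read by LC-MS, at a dose of 50 mg/kg by the oral route (on this read-out lower numbers stand for lower exposure and higher numbers for higher exposure at the dose given), compound 2 `O=C(Nc1ccc(F)c(-c2nc3ncc(-c4ccc(F)cc4)cc3[nH]2)c1)N1CCCC1` gives 10200 ng.h/mL and compound 1 `O=C(Nc1ccc(F)c(-c2nc3ncc(-c4ccc(F)cc4F)cc3[nH]2)c1)N1CCCC1` gives 15600 ng.h/mL. These two values lie within the scatter of each other. Compound 3 `Cc1nc(C)c(C(=O)Nc2ccc(F)c(-c3nc4ncc(-c5ccccc5Cl)cn4n3)c2)o1` gives 309000 ng.h/mL, well beyond the scatter of both. For the measured compounds named here, compound 2 therefore sits with compound 1 at the low end of the numbers so far.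

Compound 4 `O=C(Nc1ccc(F)c(-c2nc3ncc(-c4cccc(F)c4)cc3[nH]2)c1)N1CCCC1` has not yet been measured. It differs from compound 2 at a single place, with 3-fluorophenyl in place of 4-fluorophenyl on an aromatic carbon.

Going by the values given here, only one measured step bears on this change. It also concerns a fluoro group on an aromatic carbon, and it is a 1.5-fold lower number from compound 1 to compound 2 (0.18 log units; within the scatter), which stays within the scatter. Among the compounds with values here, compound 3 differs from compound 2 in more than one place, so it offers no comparable step, and no measured compound shows the effect of moving the fluoro group itself.

No shift beyond the scatter is therefore expected in this assay, and the estimated step is a 1.0-fold lower number from compound 2 to compound 4 (0.01 log units; within the scatter). For compound 4 the estimated value is 10000 ng.h/mL, with an expected range of 5000 ng.h/mL to 21000 ng.h/mL.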

Compound 4, area under the concentration-time curve: 15000 ng.h/mL
Compound 4: middle estimate off by 1.5-fold (0.18 log units), on the low side; the measured number falls inside the stated range.
By their numbers in this assay, from the lowest: compounds 2, 4 and 1 (each within the scatter of the next); then compound 3.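

In this assay, exchanging 4-fluorophenyl for 3-fluorophenyl on this aromatic carbon gives a 1.5-fold higher number from compound 2 to compound 4 (0.17 log units; within the scatter), which shows what the earlier step could not: the effect of the fluoro group's location on the phenyl ring, not only of its presence. Exchanging 2,4-difluorophenyl for 3-fluorophenyl gives a 1.0-fold lower number from compound 1 to compound 4 (0.02 log units; within the scatter), so compound 1, compound 2 and compound 4 all lie within the scatter of one another, and these three fluorophenyl groups are not told apart by this read-out. No measurement at hand speaks to the reason for this.

As far as these compounds go, whether a plain phenyl, a methoxyphenyl or a phenyl carrying an amine or a carboxylic acid at this place would leave the scatter remains open. Compound 3, at 309000 ng.h/mL, differs from these compounds in more than one place, so no single change can be tied to its value.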